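This account rests on a few compounds, and the source may have more. Where it says the series, first, only, none or still open, it means among the compounds named here.

Compound 1 `CC(=O)OC/C1=C/C[C@](C)(CCC=C(C)C)/C=C/[C@@H](OC(=O)C=C(C)C)[C@](C)(O)/C=C/C1=O` gives 2950 nM in a functional assay on SMMC-7721 cells (Homo sapiens) for antiproliferative activity, read by MTT assay, with a stated time of 48 h; on this read-out lower numbers stand for stronger inhibition and higher numbers for weaker inhibition.
Compound 2 `COC/C1=C/C[C@](C)(CCC=C(C)C)/C=C/[C@@H](OC(=O)C=C(C)C)[C@](C)(O)/C=C/C1=O` gives 11000 nM.
Compound 3 `CC(C)=CCC[C@]1(C)/C=C/[C@@H](OC(=O)C=C(C)C)[C@](C)(O)/C=C/C(=O)/C(CN2CCCC2)=C\C1` gives 140 nM.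

Compound 2 stands highest of the three numbers in this assay; the step of a 3.7-fold higher number from compound 1 to compound 2 (0.57 log units; beyond the scatter) separates it from compound 1, and compound 3 lies far below it. Compound 4 `CC(C)=CCC[C@]1(C)/C=C/[C@@H](OC(=O)C=C(C)C)[C@](C)(O)/C=C/C(=O)/C(Cn2cc(CO)nn2)=C\C1` differs from compound 2 by 4-(hydroxymethyl)-1H-1,2,3-triazol-1-yl in place of methoxy on a saturated chain carbon bound to a double-bonded ring carbon. Going by the values given here, the steps that bear on this change are a 79-fold lower number from compound 2 to compound 3 (1.90 log units; beyond the scatter) and a 21-fold lower number from compound 1 to compound 3 (1.32 log units; beyond the scatter), both large drops when a nitrogen-linked ring replaces the methoxy or acetoxy group at this position. The entering triazole is a different ring from pyrrolidine, so in this assay a smaller drop is expected, and the expected step is a 7.3-fold lower number from compound 2 to compound 4 (0.87 log units; beyond the scatter). Compound 4 is therefore estimated at 1500 nM, with an expected range from 400 nM to 5000 nM.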

Compound 4, half-maximal inhibitory concentration: 3560 nM
For compound 4 the middle estimate is 2.4-fold (0.38 log units) below the measured one; low and high end bracket the measured number.
By their numbers in this assay, from the lowest: compound 3; then compounds 1 and 4 (each within the scatter of the next); then compound 2.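

In this assay, a nitrogen-linked ring at this place does not in itself bring the large drop seen with pyrrolidin-1-yl: 4-(hydroxymethyl)-1H-1,2,3-triazol-1-yl gives only a 3.1-fold lower number from compound 2 to compound 4 (0.49 log units; beyond the scatter), and exchanging pyrrolidin-1-yl for it gives a 25-fold higher number from compound 3 to compound 4 (1.41 log units; beyond the scatter). Against acetoxy, the same group gives a 1.2-fold higher number from compound 1 to compound 4 (0.08 log units; within the scatter), so these two groups cannot be told apart here. Nothing available explains the gap between the two rings.

The compounds shown leave open whether a triazole without the hydroxymethyl group would behave like this one, and whether a dimethylamino group or a piperidine ring would match pyrrolidin-1-yl.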